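This account rests on a few compounds, and the source may have more. Where it says the series, first, only, none or still open, it means among the compounds named here.

Compound 1 `O=C(O)CC1(c2ccc(OCC3COc4ccc(Cl)cc4O3)cc2)COC1`: 66%
Compound 2 `CC#C[C@@H](CC(=O)O)c1ccc(OC[C@H]2COc3ccc(OC(C)C)cc3O2)cc1`: 90%

In a functional assay on HEK293 cells for agonist activity at Free fatty acid receptor 1 (Homo sapiens), read by fluorescence and calcium flux, with a stated time of 10 min (a higher number here means a larger maximal response, a lower number a smaller maximal response), compound 2 gives 90%, the highest of the two numbers available. Compound 1 gives 66% in this assay, and the gap between these two values is beyond the usual scatter, so compound 2 stands clearly above compound 1 on this read-out. Among the compounds with values here, no pair of measured compounds differs in a single place, so no measured step is available to lean on.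

Compound 3 `CC#C[C@@H](CC(=O)O)c1ccc(OC[C@H]2COc3ccc(C(=O)N4CCOCC4)cc3O2)cc1` has not yet been measured in this assay. Its structure departs from compound 2 in one place: (morpholin-4-yl)carbonyl in place of isopropoxy on an aromatic carbon. The change sits on the fused part of the shared core, well away from the acid-bearing side chain that compounds 2 and 3 have in common.

Within the data shown here, nothing among the measured compounds shows what this exchange does to the maximal response. With compound 2 already giving 90%, the room upward is small, and a step in either direction within the scatter, or none at all, is the most defensible expectation. Compound 3 is therefore expected to reach about 85% in this assay, with a plausible range from 65% to 100%. This estimate corresponds to an expected step of a number 5 percentage points lower from compound 2 to compound 3 (within the scatter), which is anticipated to fall within the usual scatter.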

Compound 3, largest response reached (Emax), in percent of the reference or control that the assay uses: 33%
Estimate against measurement, compound 3: 52 percentage points above; the measured number lies below the stated range.
By their numbers in this assay, from the lowest: compound 3; then compound 1; then compound 2.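

The exchange of isopropoxy for (morpholin-4-yl)carbonyl, on an aromatic carbon meta to a fused ring and para to a fused ring, gives a number 57 percentage points lower from compound 2 to compound 3 (beyond the scatter) in this assay. Within the data shown here, compounds 2 and 3 share the acid-bearing side chain and the rest of the core, so this single exchange carries the whole step, and the maximal response proves sensitive to what stands at this position, which the earlier compounds could not show. Nothing available explains why this exchange has so large an effect.

The entering group brings both a carbonyl and a six-membered non-aromatic ring with two hetero atoms, and compound 3 alone cannot tell which of these parts goes with the lower response. As far as these compounds go, whether a piperidin-1-ylcarbonyl group, a dimethylaminocarbonyl group or a simple methoxy group at this position would keep the response of compound 2 or lose it as compound 3 does remains open, as does whether a longer alkoxy chain such as butoxy would change it at all.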